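The source may hold more compounds than are shown below. What is called first, only, known or untested is meant among the compounds shown, and "the series" means these compounds.

Compound 1 `C=CCNc1nc(N)c(C(=O)N=C(N)N)nc1Cl` gives 16% in an assay for inhibition of acid-sensing ion channel 3 (Homo sapiens), read by patch clamp, tested at 1 uM (a lower number here means less inhibition, a higher number more inhibition at the concentration tested (going by the name of the read-out)), the lowest of the two numbers measured. Going by the values given here, compound 2 `NC(N)=NC(=O)c1nc(Cl)c(Nc2cccc(Cl)c2)nc1N` gives 47% in this assay, and the only measured step, a number 31 percentage points higher from compound 1 to compound 2 (beyond the scatter), put an aromatic ring in place of allyl. Compound 3 `NC(N)=NC(=O)c1nc(Cl)c(NCc2ccccc2F)nc1N` differs from compound 1 by 2-fluorophenyl in place of vinyl on a saturated chain carbon bound to a nitrogen on an aromatic ring, so an aromatic ring again enters, but on a saturated chain carbon bound to a nitrogen on an aromatic ring rather than on that nitrogen itself. That step bears only in part, so a smaller rise is expected. Compound 3 is estimated at 35%, between 15% and 55%. The expected step is a number 19 percentage points higher from compound 1 to compound 3 (beyond the scatter).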

Compound 3, a percentage reported as inhibition, at one concentration (the size of the read-out at that concentration, not a potency): 26%
Beside the measured number, compound 3's estimate is 9 percentage points above it; measured number inside the range.
By their numbers in this assay, from the lowest: compounds 1 and 3 (each within the scatter of the next); then compound 2.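

With 2-fluorophenyl in place of vinyl on a saturated chain carbon bound to a nitrogen on an aromatic ring, this assay gives a number 10 percentage points higher from compound 1 to compound 3 (within the scatter) and so no change that can be told from the scatter. The clear rise printed as a number 31 percentage points higher from compound 1 to compound 2 (beyond the scatter) had its ring on the nitrogen itself and does not recur with the ring on the chain carbon. Nothing measured here explains this result.

From the compounds shown here alone, the ring's attachment and its halogen both differ between these compounds, so their shares stay open. A plain phenyl group without halogen, on the nitrogen or on the chain carbon, would help separate them.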